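Swapping the aryl group on the carbonyl of compound 1

A few compounds are considered here, and "the series" means these few. Any claim that something is new, unique, unknown or untested is made for them only; others in the source may bear on it.

Three compounds share one core and differ only in the aromatic ring attached to the carbonyl carbon. Compound 1 `CCOc1ccc(C(=O)/C=C/c2c(/C=C/c3ccc(OC)cc3)cc(OC)cc2OC)cc1` was tested in a functional assay on A549 cells (Homo sapiens) for antiproliferative activity, read by MTT assay, with a stated time of 48 h (a lower number here means a stronger inhibitor, a higher number a weaker inhibitor), and compound 1 gives 7.5 ug/mL. Compound 2 `COc1ccc(/C=C/c2cc(OC)cc(OC)c2/C=C/C(=O)c2cccc(Br)c2)cc1` gives 8.1 ug/mL in this assay, and compound 3 `COc1ccc(/C=C/c2cc(OC)cc(OC)c2/C=C/C(=O)c2ccccc2C)cc1` gives 5.9 ug/mL. Compound 1 sits among these with its nearest neighbour compound 2 (a 1.1-fold higher number from compound 1 to compound 2 (0.03 log units; within the scatter)) and compound 3 a little further off (a 1.3-fold lower number from compound 1 to compound 3 (0.10 log units; within the scatter)); every step here, including a 1.4-fold lower number from compound 2 to compound 3 (0.14 log units; within the scatter), lies within the scatter, so no compound can be called stronger than another.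

Compound 4 `COc1ccc(/C=C/c2cc(OC)cc(OC)c2/C=C/C(=O)c2ccc(C)cc2C)cc1` is not yet measured. The change from compound 1 reads (2,4-dimethylphenyl in place of 4-ethoxyphenyl on a carbonyl carbon). The two measured swaps at the same place, from compound 1 to compound 2 and from compound 1 to compound 3, moved the number hardly at all, so the expectation for compound 4 in this assay is a step of about a 1.2-fold lower number from compound 1 to compound 4 (0.06 log units; within the scatter), nothing beyond the scatter. Compound 4 is therefore estimated at 6.5 ug/mL, with a likely range from 3.5 ug/mL to 12 ug/mL.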

Compound 4, half-maximal inhibitory concentration: 0.3 ug/mL
Estimate against measurement, compound 4: 22-fold (1.34 log units) above, and the stated range ends above it.
By their numbers in this assay, from the lowest: compound 4; then compounds 3, 1 and 2 (each within the scatter of the next).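

In this assay the aryl group on the carbonyl carbon proves able to move the number far beyond the scatter: 2,4-dimethylphenyl gives a 25-fold lower number from compound 1 to compound 4 (1.40 log units; beyond the scatter) and a 27-fold lower number from compound 2 to compound 4 (1.43 log units; beyond the scatter) in place of the earlier groups. The closest pair shows how little change this takes, since one methyl in place of hydrogen on an aromatic carbon, turning 2-methylphenyl into 2,4-dimethylphenyl, gives a 20-fold lower number from compound 3 to compound 4 (1.29 log units; beyond the scatter) with the rest of the molecule unchanged. No measurement shown here offers an explanation for this large step.

The compounds shown leave open whether 4-methylphenyl alone would give a similar step or whether both methyls are needed together. They also leave open whether a longer chain such as ethyl, or an amine, on that ring would keep the number this low.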